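Pentyl Amide Variant in a Cytotoxicity Series

The source may hold more compounds than are shown below. What is called first, only, known or untested is meant among the compounds shown, and "the series" means these compounds.

compound 1 `C=CC1=C(C(=O)O)C(c2ccc(F)cc2)OC1` — > 100000 nM
compound 2 `C=CC1=C(C(=O)Nc2ccc(OCC)cc2)C(c2ccc(OC)cc2)OC1` — > 100000 nM

In a functional assay on SW480 cells (Homo sapiens) for cytotoxicity, read by MTT assay, with a stated time of 24 h (a lower number here means a stronger inhibitor, a higher number a weaker inhibitor), compound 1 gives only the limit > 100000 nM. Compound 2 likewise gives only the limit > 100000 nM in this assay. Both measured values sit at the limit of > 100000 nM in this assay, at which 2 of the 2 values shown sit, so compound 2 cannot be ranked within the series. Compound 3 `C=CC1=C(C(=O)NCCCCC)C(c2ccc(OC)cc2)OC1` differs from compound 2 by pentyl in place of 4-ethoxyphenyl on an amide-type nitrogen. For the measured compounds named here, no measured step guides this change, and compound 3 is expected to show a step that the limit leaves unreadable from compound 2 to compound 3 that means nothing beyond the scatter. Compound 3 is estimated at 150000 nM, between 30000 nM and 600000 nM.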

Compound 3, half-maximal inhibitory concentration: > 100000 nM
Compound 3 gave a limit, no number; the forecaster's own chance of this, stated with the estimate: 80%; the middle value lies beyond the limit too.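

In this assay compound 3 gives the limit > 100000 nM, so no step can be read from compound 2 to compound 3: the limit of > 100000 nM in this assay, at which 3 of the 3 values shown sit.

The compounds shown leave open how pentyl and 4-ethoxyphenyl on the amide-type nitrogen compare in this assay.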